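The source may report more compounds than this note shows. Statements on the series, on what has been measured and on what is new or still open speak of the compounds shown alone.

Compound 1 `O=C(O)CC1CCN(c2ccc(OCc3ccc(Cl)cc3Cl)cc2)C1`, compound 2 `O=C(O)C[C@@H]1CCCN1c1ccc(OCc2ccc(Cl)cc2Cl)cc1` and compound 3 `O=C(O)C[C@H]1CCCN1c1ccc(OCc2ccc(Cl)cc2Cl)cc1` share one core and an acid-bearing side chain. In a functional assay on cells for agonist activity at Free fatty acid receptor 1 (Homo sapiens), read by FLIPR and calcium flux, with a stated time of 100 s (on this read-out higher numbers stand for an effect only at larger amounts of compound and lower numbers for an effect already at smaller amounts), compound 1 reaches only the limit of the assay, > 33000 nM. In this assay compound 2 gives 340 nM, the lowest of the two numbers. In this assay compound 3 gives 880 nM; the step of a 2.6-fold higher number from compound 2 to compound 3 (0.41 log units; beyond the scatter) rests on (the fact that compounds 2 and 3 differ only in the configuration as drawn). Compound 4 `Cc1cc(OCc2ccc(Cl)cc2Cl)ccc1N1CCC[C@H]1CC(=O)O` differs from compound 2 by methyl in place of hydrogen on an aromatic carbon. Going by the values given here, no measured step touches this part of the molecule, so none bears directly on it; the single step, a 2.6-fold higher number from compound 2 to compound 3 (0.41 log units; beyond the scatter), concerns configuration alone. In this assay the number for compound 4 is expected at 400 nM, with a range from 130 nM to 1500 nM. The expected step of a 1.2-fold higher number from compound 2 to compound 4 (0.07 log units; within the scatter) is none beyond the scatter.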

Compound 4, half-maximal effective concentration: 8900 nM
Compound 4: middle estimate off by 22-fold (1.35 log units), on the low side, outside the stated range (above it).
By their numbers in this assay, from the lowest: compound 2; then compound 3; then compound 4. At a limit, above all of these: compound 1.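

In this assay, one methyl on an aromatic carbon, ortho to a group of 9 heavy atoms, costs far more than the change of configuration did: (a 26-fold higher number from compound 2 to compound 4 (1.42 log units; beyond the scatter)) against (a 2.6-fold higher number from compound 2 to compound 3 (0.41 log units; beyond the scatter)). So this position of the series is sensitive to even one added carbon, which the earlier compounds could not show. Nothing in the evidence at hand bears on why this methyl has so large an effect.

From the compounds shown here alone, whether a fluorine, a hydroxyl or a methoxy group here would cost as much stays open. So does whether a methyl on the other aromatic carbons of this ring would do the same.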